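The source may hold more compounds than are shown below. What is called first, only, known or untested is meant among the compounds shown, and "the series" means these compounds.

Two compounds with a shared core carrying a phenylsulfonyl group and an anilino group have been measured. Compound 1 `O=S(=O)(c1ccccc1)c1nc2ccccc2nc1Nc1ccccc1` is the parent, and in a functional assay on PC-3 cells (Homo sapiens) for cytotoxicity, read by MTT assay, with a stated time of 72 h (a higher number here means a weaker inhibitor, a lower number a stronger inhibitor), compound 1 gives 590 nM. Compound 2 `Cc1ccc(S(=O)(=O)c2nc3ccccc3nc2Nc2ccccc2)cc1` adds a methyl group to the phenyl ring of the sulfonyl part, and in this assay compound 2 gives 1060 nM. The step of a 1.8-fold higher number from compound 1 to compound 2 (0.25 log units; within the scatter) is the only one measured, and it stays inside the scatter of the assay, so compound 2 stands at the higher of the two numbers without differing from compound 1 in any meaningful way.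

Compound 3 `COc1ccc(S(=O)(=O)c2nc3ccccc3nc2Nc2ccccc2)cc1` differs from compound 2 by methoxy in place of methyl on an aromatic carbon. Among the measured compounds shown here, only the step from compound 1 to compound 2 touches this position, and it was small. A change of the same order, with no clear direction, is therefore expected, giving an estimated step of a 1.1-fold lower number from compound 2 to compound 3 (0.03 log units; within the scatter). For compound 3 the expected value in this assay is 1000 nM, with a range from 400 nM to 2500 nM.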

Compound 3, half-maximal inhibitory concentration: 1260 nM
Beside the measured number, compound 3's estimate is 1.3-fold (0.10 log units) below it; low and high end bracket the measured number.
By their numbers in this assay, from the lowest: compounds 1, 2 and 3 (each within the scatter of the next, the first and the last beyond it).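

Methoxy in place of methyl gives a 1.2-fold higher number from compound 2 to compound 3 (0.08 log units; within the scatter) in this assay and so does not separate these two groups at this position. Methoxy in place of hydrogen gives a 2.1-fold higher number from compound 1 to compound 3 (0.33 log units; beyond the scatter) and is the first step here to pass beyond the scatter, although only modestly, so compound 3 is a somewhat weaker inhibitor than compound 1. No measurement at hand explains this shift.

Going by these compounds, both groups tested at this position leave the number close to that of compound 1, so it remains open whether a very different group there, such as an amine, a carboxylic acid or a longer chain, would move it further or in the opposite direction. On these data alone, it is also open whether a methoxy group would give a similar step elsewhere on the molecule, for example on the anilino ring.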